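The compounds below may be only part of what the source reports. "The series", "measured", "known", "first", "only" and "open" are said of these compounds alone.

Measured so far in a functional assay on a cell-free system (plasma, Homo sapiens) for inhibition, with Plasma (Rattus norvegicus) as the target; on this read-out higher numbers stand for weaker inhibition and lower numbers for stronger inhibition:
compound 1 `Cc1c(OCc2ccccc2)ccc2c(N3CCNCC3)cc(=O)oc12`: 1900 nM
compound 2 `Cc1c(OCc2cccnc2)ccc2c(N3CCNCC3)cc(=O)oc12`: 980 nM
compound 3 `CCOCOc1ccc2c(N3CCNCC3)cc(=O)oc2c1C`: 1800 nM

Compound 3, at 1800 nM, lies within the scatter of both other compounds, so the three numbers give no ranking. The next compound is compound 4 `Cc1c(OCCOc2ccccc2)ccc2c(N3CCNCC3)cc(=O)oc12`, not yet measured. It carries phenoxymethyl in place of ethoxy on a saturated chain carbon bound to an oxygen on an aromatic ring.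

Among the measured compounds shown here, three measured steps bear on this change, all made at the same place. They are a 1.1-fold lower number from compound 1 to compound 3 (0.02 log units; within the scatter), a 1.8-fold higher number from compound 2 to compound 3 (0.26 log units; within the scatter) and a 1.9-fold lower number from compound 1 to compound 2 (0.29 log units; within the scatter). Each stays within the scatter, whether the group at that place is phenyl, pyridin-3-yl or ethoxy. For the measured compounds named here, no measured compound carries phenoxymethyl, so these steps support the expectation only indirectly, and the range is kept wide on both sides. No step beyond the scatter is expected in this assay, and no direction is favoured. The expected step is a 1.1-fold lower number from compound 3 to compound 4 (0.05 log units; within the scatter). Compound 4 is estimated at 1600 nM, with an expected range of 700 nM to 3600 nM.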

Compound 4, half-maximal inhibitory concentration: 9400 nM
Compound 4: middle estimate off by 5.9-fold (0.77 log units), on the low side; measured number above the stated range.
By their numbers in this assay, from the lowest: compounds 2, 3 and 1 (each within the scatter of the next); then compound 4.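

In this assay, the place on a saturated chain carbon bound to an oxygen on an aromatic ring proves sensitive to the group it carries, with phenoxymethyl giving a 5.2-fold higher number from compound 3 to compound 4 (0.72 log units; beyond the scatter), a 4.9-fold higher number from compound 1 to compound 4 (0.69 log units; beyond the scatter) and a 9.6-fold higher number from compound 2 to compound 4 (0.98 log units; beyond the scatter), all towards weaker inhibition. Phenyl, pyridin-3-yl and ethoxy had stayed within the scatter of one another, so the tolerance suggested by compounds 1, 2 and 3 does not extend to phenoxymethyl. A six-membered aromatic ring of carbon only is not enough on its own to produce the higher number, since compound 1 also carries one and stays with compounds 2 and 3; nothing available here explains the loss.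

From the compounds shown here alone, it remains open whether the higher number follows from the greater chain length, from the ring at the end of the chain, or from the two together: butoxymethyl would keep a longer chain without the ring, and 2-phenylethyl would keep the ring without the chain oxygen. Also open, going by these compounds, is how an amine on the chain, such as dimethylaminomethyl, would read at this place.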